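The source may report more compounds than this note shows. Statements on the series, on what has been measured and on what is new or still open speak of the compounds shown alone.

Measured compounds in a functional assay on HCT-116 cells (Homo sapiens) for cytotoxicity, read by MTT assay, with a stated time of 72 h; a lower number here means a stronger inhibitor, a higher number a weaker inhibitor:
compound 1, `NCCCNc1c(C(=O)NCc2ccc(F)cc2)nc(Br)c2cccnc12`: > 20000 nM.
compound 2, `CC(C)(C)OC(=O)N1CCN(c2c(C(=O)NCc3ccc(F)cc3)nc(Br)c3cccnc23)CC1`: > 10000 nM.
compound 3, `COc1ccc(CNC(=O)c2nc(Br)c3cccnc3c2N[C@H]2CC[C@H](N)CC2)cc1`: 3000 nM.

This assay reports only a limit for compound 1, > 20000 nM, so its strength is not known as a number; it sits at the limit of > 20000 nM in this assay, at which 1 of the 3 values shown sits. For compound 2 the result is likewise a limit, > 10000 nM, which is the limit of > 10000 nM in this assay, at which 1 of the 3 values shown sits. Within the data shown here, compound 3 is the only one with a measured number, 3000 nM in this assay, and it stands as the one compound here with a usable value.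

The piece now turns to compound 4, `CNc1c(C(=O)NCc2ccc(F)cc2)nc(Br)c2cccnc12`, which has not yet been measured. Its change from compound 1 is hydrogen in place of 2-aminoethyl on a saturated chain carbon bound to a nitrogen on an aromatic ring. Put another way, 3-aminopropyl becomes methyl, so the (3-aminopropyl)amino group becomes methylamino. Among the measured compounds shown here, no two measured compounds differ in just one place, so no measured step shows what this kind of change does in this assay. For the measured compounds named here, compound 1 itself gives only a limit, and nothing among the measured compounds suggests that trimming the chain would pull compound 4 into the measurable range. The step of an at least 1.3-fold lower number from compound 1 to compound 4 (0.12 log units; that floor lies within the scatter) is therefore expected to stay within the scatter. Compound 4 is estimated at 15000 nM in this assay, with a range from 3000 nM to 60000 nM, and most likely it is reported again as a limit.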

Compound 4, half-maximal inhibitory concentration: > 20000 nM
Compound 4 ended at the assay's limit; the forecaster's own chance of this, stated with the estimate: 60%; middle value at least 1.3-fold (0.12 log units) from the limit.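

In this assay compound 4 gives > 20000 nM, which is a limit and not a number. Among these compounds, compound 1 also gives only a limit, > 20000 nM, so no step from compound 1 to compound 4 can be read. The compounds shown leave open what changing 3-aminopropyl to methyl actually does in this assay.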